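From 3,4-dimethoxyphenyl to 3,4-dihydroxyphenyl in compound 3

The source may report more compounds than this note shows. Statements on the series, on what has been measured and on what is new or still open speak of the compounds shown alone.

In a functional assay on RS4-11 cells (Homo sapiens) for inhibition, read by CCK-8 assay, with a stated time of 48 h (on this read-out lower numbers stand for stronger inhibition and higher numbers for weaker inhibition), compound 1 `COc1ccc(Oc2ccccc2-c2ccsc2S(=O)(=O)NCCNC(=S)Nc2cc(C(F)(F)F)cc(C(F)(F)F)c2)cc1OC` gives 3300 nM and compound 2 `COc1ccc(Oc2ccc(C(C)C)cc2-c2ccsc2S(=O)(=O)NCCNC(=S)Nc2cc(C(F)(F)F)cc(C(F)(F)F)c2)cc1OC` gives 5500 nM, so compound 2 stands within the scatter of compound 1. Compound 3 `CC(C)c1ccc(Oc2ccc(O)c(O)c2)c(-c2ccsc2S(=O)(=O)NCCNC(=S)Nc2cc(C(F)(F)F)cc(C(F)(F)F)c2)c1` keeps the rest of compound 2 and differs by 3,4-dihydroxyphenyl in place of 3,4-dimethoxyphenyl on an oxygen on an aromatic ring. Among the compounds with values here, the only measured step, a 1.7-fold higher number from compound 1 to compound 2 (0.22 log units; within the scatter), is isopropyl in place of hydrogen on an aromatic carbon. It is a different change, so no measurement speaks directly to this one, and no shift beyond the scatter is expected in either direction. The expected step is a 1.6-fold lower number from compound 2 to compound 3 (0.20 log units; within the scatter). For compound 3 the estimate is 3500 nM, within an expected range of 1000 nM to 9000 nM.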

Compound 3, half-maximal inhibitory concentration: 3700 nM
Compound 3: middle estimate off by 1.1-fold (0.02 log units), on the low side; low and high end bracket the measured number.
By their numbers in this assay, from the lowest: compounds 1, 3 and 2 (each within the scatter of the next).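

The step is a 1.5-fold lower number from compound 2 to compound 3 (0.17 log units; within the scatter) in this assay and so stays within the scatter. Within the data shown here, it is the first reading at this position: 3,4-dihydroxyphenyl, with 2 hydrogen-bond donors, and 3,4-dimethoxyphenyl, with 0, cannot be told apart here. No available evidence accounts for this result. Going by these compounds, it remains open whether an amine or a carboxylic acid on this ring would move the number beyond the scatter. On these data alone, it also remains open whether 3,4-dihydroxyphenyl would read the same without the isopropyl group of compound 3.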